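A few compounds are considered here, and "the series" means these few. Any claim that something is new, unique, unknown or untested is made for them only; others in the source may bear on it.

Measured compounds:
Compound 1 `Cc1cc(C(=O)c2ccccc2)ccc1OCC(=O)Nc1nc(-c2ccccc2)cs1` gives 21500 nM.
Compound 2 `Cc1ccc(C(=O)c2ccc(OCC(=O)Nc3nc(-c4ccccc4)cs3)c(C)c2)cc1` gives 25000 nM.
Compound 3 `Cc1cc(C(=O)c2ccccc2)cc(C)c1OCC(=O)Nc1nc(-c2ccccc2)cs1` gives 19100 nM.

All three were tested in a functional assay on DLA cells (Mus musculus) for cytotoxicity, read by trypan blue exclusion, with a stated time of 48 h; a lower number here means a stronger inhibitor, a higher number a weaker inhibitor. Compound 1 lies within the scatter of both neighbours: the step of a 1.1-fold lower number from compound 1 to compound 3 (0.05 log units; within the scatter) and the step of a 1.2-fold higher number from compound 1 to compound 2 (0.07 log units; within the scatter) are each too small to separate the compounds. Compound 4 `O=C(COc1ccc(C(=O)c2ccccc2)cc1Br)Nc1nc(-c2ccccc2)cs1` differs from compound 1 by bromo in place of methyl on an aromatic carbon. The two measured steps both add a methyl to an aromatic carbon rather than exchanging methyl for bromo, so they bear only indirectly on this change; they show that single substituent changes on that ring have so far moved the number within the scatter. Accordingly no step beyond the scatter is expected, a 1.1-fold lower number from compound 1 to compound 4 (0.03 log units; within the scatter). Compound 4 is estimated at 20000 nM, with a range from 10000 nM to 40000 nM.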

Compound 4, half-maximal inhibitory concentration: 42000 nM
Compound 4: the middle estimate sits 2.1-fold (0.32 log units) below what was measured; the measured number lies above the stated range.
By their numbers in this assay, from the lowest: compounds 3, 1, 2 and 4 (each within the scatter of the next, the first and the last beyond it).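

Going by these compounds alone, the methyl on this aromatic carbon, ortho to a large group and meta to a benzoyl group, had stayed in place in the earlier compounds, and compound 4 is the first in which it is exchanged. In this assay, bromo in its place gives a step still within the scatter (a 2.0-fold higher number from compound 1 to compound 4 (0.29 log units; within the scatter)), so this exchange does not separate compound 4 from compound 1. Nothing measured here offers an explanation for this step. As far as these compounds go, how an amine or a carboxylic acid on this carbon would read remains open. So does whether any group at this position can produce a step beyond the scatter.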